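Swapping the aryl ring on a chalcone-type lactam

The compounds below may be only part of what the source reports. "The series", "measured", "known", "first", "only" and "open" are said of these compounds alone.

Measured compounds:
compound 1 `O=C(COc1ccc(C(=O)/C=C/c2ccccc2Cl)cc1)N[C@H]1CCOC1=O` gives 4610 nM
compound 2 `O=C1OCC[C@@H]1NC(=S)SCCOc1ccc([N+](=O)[O-])cc1` gives 32500 nM
compound 3 `O=C1OCC[C@@H]1NC(=S)SCCOc1ccccc1` gives > 64000 nM

In a functional assay on PC-3 cells (Homo sapiens) for antiproliferative activity, read by MTT assay, with a stated time of 72 h (a higher number here means a weaker inhibitor, a lower number a stronger inhibitor), compound 1 gives the lowest of the two numbers, with compound 2 standing at a higher value, a gap beyond the scatter. Compound 3 gives only a limit of the assay, (the limit of > 64000 nM in this assay, at which 1 of the 3 values shown sits). Within the data shown here, the step of an at least 1.9-fold higher number from compound 2 to compound 3 (0.29 log units; that floor lies within the scatter) is the single measured step, and it concerns a different part of a different scaffold. Compound 4 `O=C(COc1ccc(C(=O)/C=C/c2ccc(F)cc2)cc1)N[C@H]1CCOC1=O` differs from compound 1 by 4-fluorophenyl in place of 2-chlorophenyl on a double-bonded chain carbon bound to a double-bonded chain carbon. Among the measured compounds shown here, no measured step bears on this change, so the expectation rests on compound 1 alone and on the scatter of the method. Compound 4 is therefore expected to lie close to compound 1, with a step of a 1.1-fold higher number from compound 1 to compound 4 (0.04 log units; within the scatter) not beyond the scatter. The estimate for compound 4 is 5000 nM, ranging from 2000 nM to 15000 nM.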

Compound 4, half-maximal inhibitory concentration: 15600 nM
The estimate for compound 4 lay 3.1-fold (0.49 log units) below the measured number; the measured number lies above the stated range.
By their numbers in this assay, from the lowest: compound 1; then compound 4; then compound 2. At a limit, above all of these: compound 3.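

In this assay, among these compounds, the change to 4-fluorophenyl from 2-chlorophenyl gives a 3.4-fold higher number from compound 1 to compound 4 (0.53 log units; beyond the scatter) and so shows that this position on the chain responds to the choice of aryl group, which no earlier step could show. The two groups match in heavy-atom count and in hydrogen-bond donors and acceptors, so those counts do not separate them. Nothing measured here accounts for the step. Halogen and its place on the ring change together, so their separate shares remain open. On these data alone, how an amine or a carboxylic acid on that ring would read also remains open.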